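A chloro-to-bromo swap in a small series

The source may hold more compounds than are shown below. What is called first, only, known or untested is meant among the compounds shown, and "the series" means these compounds.

In an ADME assay on CCRF-CEM cells (Homo sapiens) for antiproliferative activity, with a stated time of 48 h (on this read-out lower numbers stand for stronger inhibition and higher numbers for weaker inhibition), compound 1 `C=C(Br)C(=O)Nc1ccc(/C=C/C(=O)c2ccc(Br)cc2)cc1` gives 990 nM, compound 2 `Nc1ccc(/C=C/C(=O)c2ccccc2)cc1` gives 34000 nM and compound 3 `Nc1ccc(/C=C/C(=O)c2ccc(Cl)cc2)cc1` gives 21000 nM. Compound 3 therefore sits close to compound 2, with a far higher number than compound 1. Compound 4 `Nc1ccc(/C=C/C(=O)c2ccc(Br)cc2)cc1` brings (bromo in place of chloro on an aromatic carbon), bromo in place of chloro on an aromatic carbon. Among the compounds with values here, the one measured step that bears on this change is a 1.6-fold lower number from compound 2 to compound 3 (0.21 log units; within the scatter), with chloro in place of hydrogen. Compound 1 also carries bromo but has a further group, so it says little about this swap. In this assay, the expected result is therefore no step beyond the scatter: an estimated 1.1-fold lower number from compound 3 to compound 4 (0.04 log units; within the scatter). For compound 4, the estimated value is 19000 nM, with an expected range of 10000 nM to 36000 nM.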

Compound 4, half-maximal inhibitory concentration: 14000 nM
The estimate for compound 4 lay 1.4-fold (0.13 log units) above the measured number; low and high end bracket the measured number.
By their numbers in this assay, from the lowest: compound 1; then compounds 4, 3 and 2 (each within the scatter of the next, the first and the last beyond it).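

The swap itself gives a 1.5-fold lower number from compound 3 to compound 4 (0.18 log units; within the scatter) and so separates the two halogens no better than repeat measurements would. Bromo in place of hydrogen gives a 2.4-fold lower number from compound 2 to compound 4 (0.39 log units; beyond the scatter) and is the first change at this ring position to pass the scatter, though only modestly. Hydrogen in place of (1-bromoethenyl)carbonyl on the nitrogen gives a 14-fold higher number from compound 1 to compound 4 (1.15 log units; beyond the scatter) and is the largest of these steps. Nothing measured here explains any of these steps. Open, on these data alone, is how a methoxy group or a nitrile at this ring position would compare with the halogens.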